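Replacing one aromatic group in compound 3

This account rests on a few compounds, and the source may have more. Where it says the series, first, only, none or still open, it means among the compounds named here.

Measured so far in a functional assay on DU-145 cells (Homo sapiens) for inhibition, read by trypan blue exclusion, with a stated time of 96 h; a higher number here means a weaker inhibitor of growth, a lower number a stronger inhibitor of growth
compound 1 `O=C(/C(=C\c1ccc(Br)cc1)SCc1ccc(Cl)cc1)c1ccc(Br)cc1` gives 1000 nM
compound 2 `Cc1ccc(S/C(=C/c2ccc(Br)cc2)C(=O)c2ccc(Cl)cc2)cc1` gives 25000 nM
compound 3 `O=C(/C(=C\c1ccc(O)cc1O)SCc1ccc(Cl)cc1)c1ccc(Cl)cc1` gives 50000 nM

Compound 3 (50000 nM) cannot be told apart from compound 2 (25000 nM), since the two lie within the usual scatter. Compound 1 (1000 nM) has a much lower number than compound 3, a gap beyond the scatter, and a lower number marks a stronger inhibitor of growth.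

Compound 4 `O=C(/C(=C\c1ccc(Br)cc1)SCc1ccc(Cl)cc1)c1ccc(Cl)cc1` differs from compound 3 in one place (4-bromophenyl in place of 2,4-dihydroxyphenyl on a double-bonded chain carbon bound to a double-bonded chain carbon): 4-bromophenyl in place of 2,4-dihydroxyphenyl on a double-bonded chain carbon bound to a double-bonded chain carbon.

For the measured compounds named here, no measured pair here differs in only one place, so no direct step shows how large this change might be. The best guide is compound 1, which also carries 4-bromophenyl there and gives 1000 nM in this assay. Compound 2 goes against this guide: it carries the same group yet gives 25000 nM, so the group does not go with a low number in every case. With wide uncertainty, the expected step is a 20-fold lower number from compound 3 to compound 4 (1.30 log units; beyond the scatter). Compound 4 is expected at 2500 nM (estimated range 700 nM to 12000 nM).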

Compound 4, concentration for 50% growth inhibition: 1000 nM
The estimate for compound 4 lay 2.5-fold (0.40 log units) above the measured number; the range from low to high includes it.
By their numbers in this assay, from the lowest: compounds 1 and 4 (each within the scatter of the next); then compounds 2 and 3 (each within the scatter of the next).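

In this assay, for the compounds shown here, 4-bromophenyl in place of 2,4-dihydroxyphenyl on a double-bonded chain carbon gives a 50-fold lower number from compound 3 to compound 4 (1.70 log units; beyond the scatter), the first step in which only this group changes, and it shows that the group at this place can strongly shift growth inhibition. The 4-bromophenyl group alone does not settle the outcome: with it held fixed, 4-chlorobenzyl in place of 4-methylphenyl on a sulfur gives a 25-fold lower number from compound 2 to compound 4 (1.40 log units; beyond the scatter), whereas chloro in place of bromo on an aromatic carbon gives no change at the digits printed from compound 1 to compound 4 (within the scatter). No measurement shown here explains why either large step occurs.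

The compounds shown leave open whether the large step from 2,4-dihydroxyphenyl to 4-bromophenyl comes from losing the two hydroxy groups, from gaining the bromine, or from both. As far as these compounds go, it also remains open where a plain phenyl, a methoxyphenyl or an aminophenyl group at this place would fall in this assay.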